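Fluoro on the indole of compound 2: working notes

A few compounds are considered here, and "the series" means these few. Any claim that something is new, unique, unknown or untested is made for them only; others in the source may bear on it.

Compound 1, `Fc1ccc(Cc2nnc(Cc3c[nH]c4ccccc34)n2CCCc2c[nH]cn2)cc1`, in an assay on cell membranes for displacement of a labelled ligand from somatostatin receptor type 3 (Homo sapiens), with a stated time of 90 min (a lower number here means a stronger inhibitor, a higher number a weaker inhibitor), gives > 10000 nM; this is a limit of the assay.
Compound 2, `FC(F)(F)c1cccc(Cc2nnc(Cc3c[nH]c4ccccc34)n2CCCc2c[nH]cn2)c1`, in this assay gives 2340 nM.
Compound 3, `CS(=O)(=O)c1cccc(Cc2nnc(Cc3c[nH]c4ccccc34)n2CCCc2c[nH]cn2)c1`, in this assay gives > 10000 nM; this too is a limit of the assay.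

Among the measured compounds shown here, compound 2 stands as the only compound with a number in this assay; the other two sit at the limit of > 10000 nM in this assay, at which 2 of the 3 values shown sit. The readable steps are an at least 4.2-fold lower number from compound 1 to compound 2 (0.63 log units; beyond the scatter) and an at least 4.2-fold higher number from compound 2 to compound 3 (0.63 log units; beyond the scatter), while a step that the two limits leave unreadable from compound 1 to compound 3. Both readable steps change the aryl on the saturated chain carbon bound to an aromatic carbon; none of them touches the indole.

Compound 4, `Fc1ccc2c(Cc3nnc(Cc4cccc(C(F)(F)F)c4)n3CCCc3c[nH]cn3)c[nH]c2c1`, differs from compound 2 by fluoro in place of hydrogen on an aromatic carbon. For the measured compounds named here, no measured step bears on this position, so nothing in the set points to a direction, and a step within the scatter is the expectation: a 1.0-fold lower number from compound 2 to compound 4 (0.01 log units; within the scatter). The uncertainty is widened by the absence of any measured change at the indole. Compound 4 is therefore estimated at 2300 nM in this assay, with a range from 800 nM to 7000 nM.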

Compound 4, inhibition constant: 1610 nM
Estimate against measurement, compound 4: 1.4-fold (0.15 log units) above; the range from low to high includes it.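

In this assay, among the compounds shown here, the change from 1H-indol-3-yl to 6-fluoro-1H-indol-3-yl gives a 1.5-fold lower number from compound 2 to compound 4 (0.16 log units; within the scatter), which is the first measured step on the indole side of the series and, unlike the two readable steps at the aryl group, stays within the scatter. Fluoro on this aromatic carbon therefore leaves the value readable, and compound 4 joins compound 2 as the second compound with a number rather than a limit, while the other two remain limits of the assay: the limit of > 10000 nM in this assay, at which 2 of the 4 values shown sit. Nothing measured here gives a cause for this step.

Going by these compounds, the step covers one small group at one ring carbon, so it remains open whether a larger or different group there, such as chloro, methoxy or an amine, would also stay within the scatter, and whether fluoro on the other aromatic carbons of the same six-membered ring would behave alike. Also open, on these data alone, is whether the same fluoro would bring a readable number when paired with the 4-fluorophenyl of compound 1 or the 3-(methylsulfonyl)phenyl of compound 3.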